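Alkoxy variation on the aminoquinoline-type core: isopropyl ether

The compounds below may be only part of what the source reports. "The series", "measured", "known", "first", "only" and "open" are said of these compounds alone.

Measured so far:
compound 1 `Nc1ccc2cccc(OC3CCCCC3)c2n1`, an assay on cells with melanin-concentrating hormone receptor 1 (Homo sapiens) as the target, read by radioligand binding (on this read-out higher numbers stand for weaker inhibition and lower numbers for stronger inhibition), 361 nM
compound 2 `CC1CC1COc1cccc2ccc(N)nc12`, this assay 1640 nM

Among the measured compounds shown here, compound 2 stands at the higher of the two numbers; the only step, a 4.5-fold higher number from compound 1 to compound 2 (0.66 log units; beyond the scatter), shows the smaller ring-bearing ether weakening inhibition. Compound 3 `CC(C)Oc1cccc2ccc(N)nc12` carries the change (isopropyl in place of (2-methylcyclopropyl)methyl on an oxygen on an aromatic ring). For the measured compounds named here, no measured step covers this exact change; the single step available, from a larger to a smaller ether group, went beyond the scatter, so a further modest rise is expected rather than none. Compound 3 is estimated at 2500 nM (range 800 nM to 8000 nM), an expected step of a 1.5-fold higher number from compound 2 to compound 3 (0.18 log units; within the scatter).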

Compound 3, half-maximal inhibitory concentration: 437 nM
The estimate for compound 3 lay 5.7-fold (0.76 log units) above the measured number, outside the stated range (below it).
By their numbers in this assay, from the lowest: compounds 1 and 3 (each within the scatter of the next); then compound 2.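

In this assay, isopropyl in place of (2-methylcyclopropyl)methyl on this oxygen gives a 3.8-fold lower number from compound 2 to compound 3 (0.57 log units; beyond the scatter) and so reverses the loss seen with the earlier step, while isopropyl in place of cyclohexyl gives a 1.2-fold higher number from compound 1 to compound 3 (0.08 log units; within the scatter) and stays within the scatter. Among these three ethers the number therefore does not follow group size: compound 2 goes against any such trend, and a small group on this oxygen is compatible with a number matching that of the cyclohexyl ether. No available evidence bears on this result.

Still open, on these data alone, is whether the three-membered ring or its methyl goes with the higher number of compound 2. Cyclopropylmethyl and a straight butyl chain on the same oxygen would separate the two.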